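Compound 3 to Compound 4: Swapping the Aryl Group

A few compounds are considered here, and "the series" means these few. Any claim that something is new, unique, unknown or untested is made for them only; others in the source may bear on it.

Compound 1 `COc1cc(C(=O)c2sc(-c3ccc([N+](=O)[O-])cc3)cc2N)cc(OC)c1OC`: 110 nM
Compound 2 `COc1cc(C(=O)c2sc(-c3ccccc3Cl)cc2N)cc(OC)c1OC`: 17 nM
Compound 3 `COc1cc(C(=O)c2sc(-c3ccc(F)cc3)cc2N)cc(OC)c1OC`: 12 nM

In a functional assay on MOLT-4 cells (Homo sapiens) for antiproliferative activity (on this read-out lower numbers stand for stronger inhibition and higher numbers for weaker inhibition), compound 3 gives 12 nM, at the low end of the three values and level with compound 2 within the scatter. Compound 4 `COc1cccc(-c2cc(N)c(C(=O)c3cc(OC)c(OC)c(OC)c3)s2)c1` carries 3-methoxyphenyl in place of 4-fluorophenyl on an aromatic carbon. Two measured steps change this same aryl group, a 1.4-fold lower number from compound 2 to compound 3 (0.15 log units; within the scatter) and a 9.2-fold lower number from compound 1 to compound 3 (0.96 log units; beyond the scatter). Neither introduces a methoxy group, so they offer only a guide to size. No step beyond the scatter is expected, and the expected change is a 1.5-fold higher number from compound 3 to compound 4 (0.18 log units; within the scatter). The estimate for compound 4 is 18 nM, with an expected range from 6 nM to 60 nM.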

Compound 4, half-maximal inhibitory concentration: 17 nM
The estimate for compound 4 lay 1.1-fold (0.02 log units) above the measured number; the range from low to high includes it.
By their numbers in this assay, from the lowest: compounds 3, 2 and 4 (each within the scatter of the next); then compound 1.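

In this assay this aryl position on the thiophene-free shared core also holds a methoxy group: 3-methoxyphenyl gives a 1.4-fold higher number from compound 3 to compound 4 (0.15 log units; within the scatter) against 4-fluorophenyl and no change at the digits printed from compound 2 to compound 4 (within the scatter) against 2-chlorophenyl, both within the scatter. Against 4-nitrophenyl, the same group gives a 6.5-fold lower number from compound 1 to compound 4 (0.81 log units; beyond the scatter) and lies beyond the scatter, so the nitro compound alone stands apart among the four. Nothing measured here accounts for these values. Open, from the compounds shown here alone, is whether 2-methoxyphenyl or 4-methoxyphenyl would read like 3-methoxyphenyl. Also open, going by these compounds, is how a phenyl ring bearing an amine or a carboxylic acid would behave at this position.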